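Swapping chloro for fluoro on a thiophene-linked amidine

The source may hold more compounds than are shown below. What is called first, only, known or untested is meant among the compounds shown, and "the series" means these compounds.

Measured so far:
- compound 1, `N=C(N)c1ccc(-c2ccc(-c3ccc(Cl)cc3)s2)s1`: 49%
- compound 2, `N=C(N)c1ccc(-c2ccc(-c3cc(Cl)cc(Cl)c3)o2)o1`: 57.1%
- compound 3, `N=C(N)c1ccc(-c2ccc(-c3cc(Cl)cc(Cl)c3)s2)s1`: 6.7%

In an ADME assay on cells (Erythrocyte, Homo sapiens) for activation, read by hemolysis, with a stated time of 30 min, tested at 5 mM (a lower number here means a weaker effect, a higher number a stronger effect of the compound at the concentration tested), compound 1 gives 49%, the second highest of the three numbers. Compound 2 sits within the scatter of it, so no order between the two can be read. Compound 3, with two chlorines on the outer ring, lies far lower, beyond the scatter.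

Compound 4, `N=C(N)c1ccc(-c2ccc(-c3ccc(F)cc3)s2)s1`, has not been measured. It differs from compound 1 in one place: fluoro in place of chloro on an aromatic carbon. The change keeps atom count, ring and charge the same; only the halogen differs. Within the data shown here, nothing among the measured compounds shows what a single fluoro does here. A small step is expected, no larger than the scatter, from compound 1 to compound 4 of a number 7 percentage points lower from compound 1 to compound 4 (within the scatter). Compound 4 is therefore estimated at 42%, with a range from 15% to 70%.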

Compound 4, a percentage reported as activity, at one concentration (the size of the read-out at that concentration, not a potency): 59.7%
Estimate against measurement, compound 4: 17.7 percentage points below; measured number inside the range.
By their numbers in this assay, from the lowest: compound 3; then compounds 1, 2 and 4 (each within the scatter of the next, the first and the last beyond it).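

Among these compounds, at this position, on an aromatic carbon para to a large group, the choice of halogen alone moves the read-out: in this assay fluoro in place of chloro gives a number 10.7 percentage points higher from compound 1 to compound 4 (beyond the scatter) and this modest step is the first single-place change seen in this set. The ring and net charge stay the same across the step. No measurement here gives a reason for the step.
As far as these compounds go, whether bromo, methyl or an amine at the same place would give a higher or lower number stays open. From the compounds shown here alone, it is also open whether the same swap would give a similar step on another core.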